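Swapping a Pyrrolidine Amide for a Morpholine Amide

This account rests on a few compounds, and the source may have more. Where it says the series, first, only, none or still open, it means among the compounds named here.

Of the compounds shown here, three sharing one core have been tested in a functional assay on the whole organism (strain Wistar) for inhibition, with Rattus norvegicus as the target, read by paw edema, with stated times of 60 min and 2 h, at a dose of 100 mg/kg by the oral route; a lower number here means less inhibition, a higher number more inhibition at the dose given (going by the name of the read-out). Compound 1 `COc1cc2c(cc1OC)C(CC(=O)O)CC2` carries a hydroxy group on its carbonyl carbon and gives 24%. Compound 2 `CCCCCCNC(=O)CC1CCc2cc(OC)c(OC)cc21`, with hexylamino on that carbon, gives 41.5%. Compound 3 `COc1cc2c(cc1OC)C(CC(=O)N1CCCC1)CC2`, with pyrrolidin-1-yl there, gives 20%, the smallest of the three numbers; against compound 1 it stands within the scatter, as a number 4 percentage points lower from compound 1 to compound 3 (within the scatter) shows, and only against compound 2 does it stand apart, as a number 21.5 percentage points lower from compound 2 to compound 3 (beyond the scatter) shows.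

Compound 4 `COc1cc2c(cc1OC)C(CC(=O)N1CCOCC1)CC2` has not yet been measured. It differs from compound 3 in one place: morpholin-4-yl in place of pyrrolidin-1-yl on a carbonyl carbon. For the measured compounds named here, no measured step exchanges one ring amine for another on the carbonyl carbon; the steps touching that position are a number 4 percentage points lower from compound 1 to compound 3 (within the scatter) and a number 21.5 percentage points lower from compound 2 to compound 3 (beyond the scatter), and neither involves morpholin-4-yl, so there is no direct guide. The expected step of a number 2 percentage points higher from compound 3 to compound 4 (within the scatter) in this assay is therefore small, with no direction beyond the scatter claimed. Compound 4 is estimated at 22%, within a range from 8% to 38%.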

Compound 4, a percentage reported as inhibition, in the whole organism at one dose (the size of the read-out at that dose, not a potency): 14%
The estimate for compound 4 lay 8 percentage points above the measured number, and the stated range covers the measured number.
By their numbers in this assay, from the lowest: compounds 4, 3 and 1 (each within the scatter of the next); then compound 2.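

For the compounds shown here, exchanging one ring amine for another on the carbonyl carbon gives the first direct reading of such a swap, and in this assay the larger morpholin-4-yl ring with its oxygen leaves no clear mark: a number 6 percentage points lower from compound 3 to compound 4 (within the scatter). The morpholin-4-yl group also cannot be told apart from hydroxy on that carbon, a number 10 percentage points lower from compound 1 to compound 4 (within the scatter), whereas the gap to hexylamino is clear, a number 27.5 percentage points lower from compound 2 to compound 4 (beyond the scatter). Nothing measured here explains these numbers.

Hexylamino is the only open chain on this carbon and the only amine shown that keeps its amide hydrogen, so the compounds cannot say which of these features goes with the higher number. Butylamino and dimethylamino on the same carbon would help to separate the two.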